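A few compounds are considered here, and "the series" means these few. Any claim that something is new, unique, unknown or untested is made for them only; others in the source may bear on it.

Going by the values given here, in a functional assay on HepG2 cells (Homo sapiens) for inhibition, read by MTT assay, with a stated time of 24 h (on this read-out lower numbers stand for stronger inhibition and higher numbers for weaker inhibition), compound 1 (`COc1ccc(/C=N/NC(=O)CNC(=O)c2ccc(F)cc2)c(OCc2ccccc2Cl)c1`) gives 15700 nM as the only number so far. Compound 2 (`CCN(CC)c1ccc(/C=N/NC(=O)CNC(=O)c2ccc(C)cc2)c(OCc2ccccc2Cl)c1`) stands at > 50000 nM as a limit of this assay and not a number. Compound 3 (`COc1ccc(/C=N/NC(=O)CNC(=O)c2ccc(C)cc2)c(OCc2ccccc2Cl)c1`) follows from compound 2 with methoxy in place of diethylamino on an aromatic carbon, para to a large group, and the counted difference is methoxy in place of diethylamino on an aromatic carbon for this change. Among the compounds with values here, no measured step gives its size. Within the data shown here, a move beyond the scatter towards stronger inhibition is expected in this assay, resting on compound 1 at 15700 nM as the one measured compound with methoxy in that place. The expected shift is an at least 2.5-fold lower number from compound 2 to compound 3 (0.39 log units; beyond the scatter) on this estimate. Compound 3 is estimated at 20000 nM in this assay, with an expected range from 7000 nM to 50000 nM for the coming measurement.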

Compound 3, half-maximal inhibitory concentration: > 50000 nM
Compound 3 ended at the assay's limit; the forecaster's own chance of this, stated with the estimate: 15%; at least 2.5-fold (0.39 log units) between middle value and limit.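

In this assay, going by these compounds alone, compound 3 sits at a limit of the assay, as compound 2 does, so the step between them cannot be read: the limit of > 50000 nM in this assay, at which 2 of the 3 values shown sit. With methoxy held constant, methyl in place of fluoro on an aromatic carbon gives the first readable step, an at least 3.1-fold higher number from compound 1 to compound 3 (0.50 log units; beyond the scatter). Methoxy on this aromatic carbon, para to a large group, therefore does not bring a measurable value on its own; among the compounds shown, a measured value appears only where methoxy and fluoro occur together, in compound 1.

On these data alone, it remains open whether fluoro would give a measurable value with diethylamino in the methoxy place. As far as these compounds go, how chloro or trifluoromethyl in the place of fluoro would read in this assay is also open.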